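The source may report more compounds than this note shows. Statements on the series, on what has been measured and on what is new or still open speak of the compounds shown alone.

Measured so far in a functional assay on SEM cells (Homo sapiens) for cytotoxicity, with a stated time of 72 h; a higher number here means that more compound is needed for the effect, a lower number that less compound is needed:

- Compound 1 `C=C[C@@](C)(/C=C/c1ccc(OS(=O)(=O)C(F)(F)F)cc1)CCC=C(C)C` gives > 36600 nM as a limit
- Compound 2 `C=C[C@](C)(CCCC(C)C)CCc1ccc(O)cc1` gives > 36600 nM as a limit
- Compound 3 `C=C[C@@](C)(/C=C/c1ccc(O)cc1)CCC(O)C(C)(C)O` gives > 36600 nM as a limit

None of these entries is a true number. Among the measured compounds shown here, each says only that the assay reached its limit, and the whole series so far sits at the limit of > 36600 nM in this assay, at which 3 of the 3 values shown sit, without exception.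

Compound 3 stands at > 36600 nM in this assay and this too is a limit, so the starting point of the next step is not a number.

Compound 4 `C=C[C@@](C)(/C=C/c1ccc(O)cc1)CCCO` differs from compound 3 in one place, counted as hydrogen in place of 1-hydroxy-1-methylethyl on a saturated chain carbon bound to an oxygen on a saturated carbon and a saturated chain carbon in the comparison of the two structures. Hydrogen takes the place of 1-hydroxy-1-methylethyl on a saturated chain carbon bound to an oxygen on a saturated carbon and a saturated chain carbon. Cut one bond further out, the same difference reads 2,3-dihydroxy-3-methylbutyl to 2-hydroxyethyl.

For the measured compounds named here, no measured pair shows what a change of this kind does. The expectation is therefore no step beyond the usual scatter, and the estimate amounts to an expected step that the limit leaves unreadable from compound 3 to compound 4 in this assay.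

For compound 4 the expected value is 40000 nM with an estimated range from 20000 nM to 80000 nM and a limit instead of a number is the likeliest outcome.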

Compound 4, half-maximal effective concentration: > 36600 nM
Compound 4 ended at the assay's limit; the forecaster's own chance of this, stated with the estimate: 80%; the middle value is on the limit's open side.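

Among the compounds shown here, compound 4 ends at a limit rather than a true number, as compound 3 does, so no step between compound 3 and compound 4 can be read: the limit of > 36600 nM in this assay, at which 4 of the 4 values shown sit. The compounds shown leave open at what concentration, if any, they have an effect, and whether hydrogen in place of 1-hydroxy-1-methylethyl changes it.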